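Notes on the step from compound 1 to compound 4

The source may hold more compounds than are shown below. What is called first, only, known or untested is meant among the compounds shown, and "the series" means these compounds.

In an ADME assay on microsomes from liver (Mus musculus) for metabolic stability, read by LC-MS, using NADPH, with a stated time of 30 min, tested at 0.1 uM (a higher number here means that more of the compound is left, a lower number that less of the compound is left), the measured compounds read as follows
- compound 1 `O=S(=O)(c1cccc(-c2ccc3nccc(-c4ccncc4)c3n2)c1)N1CCC(O)CC1` gives 7%
- compound 2 `O=S(=O)(NCCO)c1cccc(Nc2ccc3nccc(-c4ccncc4)c3n2)c1` gives 38%
- compound 3 `NS(=O)(=O)c1ccc(-c2ccc3nccc(-c4ccncc4)c3n2)cc1` gives 13%

Compound 1 lies within the scatter of compound 3 and, beyond the scatter, under compound 2, so it stands at the low end of these numbers. Compound 4 `Nc1cccc(-c2ccc3nccc(-c4ccncc4)c3n2)c1` keeps the shared core and carries amino in place of (4-hydroxypiperidin-1-yl)sulfonyl on an aromatic carbon. Within the data shown here, no measured pair isolates this change, so the expectation rests on the three values alone. A small upward step, not beyond the scatter, is expected in this assay (a number 8 percentage points higher from compound 1 to compound 4 (within the scatter)). Compound 4 is estimated at 15% (expected range 5% to 35%).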

Compound 4, percent of the compound remaining: 54%
Beside the measured number, compound 4's estimate is 39 percentage points below it; the measured number lies above the stated range.
By their numbers in this assay, from the lowest: compounds 1 and 3 (each within the scatter of the next); then compound 2; then compound 4.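

In this assay, amino in place of (4-hydroxypiperidin-1-yl)sulfonyl on an aromatic carbon, meta to a large group, gives a large rise (a number 47 percentage points higher from compound 1 to compound 4 (beyond the scatter)). Among these compounds, this is the first readable single-place step, and it shows that the read-out at this position responds strongly to the group carried there. No available measurement bears on the reason for this rise.

From the compounds shown here alone, it remains open whether the rise follows from the presence of amino or the absence of the sulfonyl group. An acetamide or a carboxylic acid at the same place would help separate the two.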